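Acetoxy to ((pyridin-3-yl)carbonyl)oxy on compound 2

The source may hold more compounds than are shown below. What is called first, only, known or untested is meant among the compounds shown, and "the series" means these compounds.

In a functional assay on HeLa cells (Homo sapiens) for inhibition, read by MTT assay, with a stated time of 72 h, tested at 30 ug/mL (a lower number here means less inhibition of growth, a higher number more inhibition of growth at the concentration tested), compound 2 `C=C1[C@H](OC(C)=O)C[C@@H](OC(C)=O)C(C)(C)/C=C/[C@@H](C)C(=O)[C@@]2(OC(C)=O)C[C@@](C)(OC(C)=O)[C@H](OC(C)=O)[C@@H]2[C@H]1OC(C)=O` gives 26.7% and compound 3 `CC(=O)O[C@H]1[C@H]2OC(=O)CC[C@](O)([C@@H]1OCC(C)C)[C@H](OC(C)=O)[C@H]1[C@@H](OC(C)=O)[C@](C)(OC(C)=O)C[C@]1(OC(C)=O)C(=O)[C@H](C)[C@H]1O[C@@H]1C2(C)C` gives 20.8% within the scatter of each other, together at the upper end of the three numbers. Compound 1 `C=C1[C@H](OCC(C)C)C[C@@H](OC(=O)c2cccnc2)C(C)(C)/C=C/[C@@H](C)C(=O)[C@@]2(OC(C)=O)C[C@H](C)[C@H](OC(C)=O)[C@@H]2[C@H]1OC(C)=O` gives 4.5% which lies beyond the scatter lower than compound 2. Compound 4 `C=C1[C@H](OC(C)=O)C[C@@H](OC(=O)c2cccnc2)C(C)(C)/C=C/[C@@H](C)C(=O)[C@@]2(OC(C)=O)C[C@@](C)(OC(C)=O)[C@H](OC(C)=O)[C@@H]2[C@H]1OC(C)=O` replaces one acetoxy of compound 2 with ((pyridin-3-yl)carbonyl)oxy (pyridin-3-yl in place of methyl on a carbonyl carbon) and thus has pyridin-3-yl in place of methyl on a carbonyl carbon. Within the data shown here, no measured pair shows this change alone. Compound 1 carries the same ((pyridin-3-yl)carbonyl)oxy group on a core differing elsewhere, and its 4.5% value points to a modest fall in this assay rather than a rise. The expected step is a number 9.7 percentage points lower from compound 2 to compound 4 (within the scatter) and may stay within the scatter. Compound 4 is estimated at 17% with an expected range of 5% to 30% in this measurement.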

Compound 4, percent growth inhibition at one concentration: 17.9%
Compound 4: middle estimate off by 0.9 percentage points, on the low side; low and high end bracket the measured number.
By their numbers in this assay, from the lowest: compound 1; then compounds 4, 3 and 2 (each within the scatter of the next).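

Pyridin-3-yl in place of methyl on a carbonyl carbon can now be read alone: in this assay the step is a number 8.8 percentage points lower from compound 2 to compound 4 (within the scatter). At this place, the change from acetoxy to ((pyridin-3-yl)carbonyl)oxy therefore leaves the number within the scatter, which compound 1, differing elsewhere as well, could not show. Nothing available here explains the step.

Open, going by these compounds, is how other groups on this carbonyl carbon would read, such as phenyl, pyridin-4-yl or an aminomethyl chain. Also open, on these data alone, is whether the same change reads alike on a different core.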